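The source may hold more compounds than are shown below. What is called first, only, known or untested is meant among the compounds shown, and "the series" means these compounds.

Of the compounds shown here, three built on a shared core have been tested in a functional assay on PC-3 cells (Homo sapiens) for antiproliferative activity, read by MTT assay, with a stated time of 72 h; on this read-out lower numbers stand for stronger inhibition and higher numbers for weaker inhibition. Compound 1 `CC(C)c1ccc(NCC(=O)N[C@H]2CCOC2=O)cc1` gives > 64000 nM there, which is a limit of the assay and not a number. Compound 2 `O=C(CNc1ccccc1F)N[C@H]1CCOC1=O` likewise reaches only a limit in this assay, > 64000 nM. Compound 3 `O=C(CNc1cccc(Cl)c1)N[C@H]1CCOC1=O` also returns only a limit in this assay, > 64000 nM. For the measured compounds named here, compound 3 thus stands where every value so far sits, at the limit of > 64000 nM in this assay, at which 3 of the 3 values shown sit, so no ordering among the three compounds can be read from these numbers. Compound 4 `O=C(CNc1ccccc1)N[C@H]1CCOC1=O` differs from compound 3 by hydrogen in place of chloro on an aromatic carbon, meta to a large group. Going by the values given here, no step between measured compounds exists against which this change could be weighed. With compound 3 showing only a limit in this assay, the expected step that the limit leaves unreadable from compound 3 to compound 4 is estimated as none beyond the scatter. Compound 4 is therefore expected to give about 90000 nM in this assay, within a range from 30000 nM to 300000 nM, most likely again reported only as a limit.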

Compound 4, half-maximal inhibitory concentration: > 64000 nM
Compound 4: a limit, no number; the forecaster's own chance of this, stated with the estimate: 90%; the middle value lies beyond the limit too.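

In this assay compound 4 gives > 64000 nM as a limit and not a number. The steps to compound 4 from compound 1, compound 2 and compound 3 therefore cannot be read: the limit of > 64000 nM in this assay, at which 4 of the 4 values shown sit. The compounds shown leave open how far any of these aromatic substituents matters, since none yields a number.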